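Ester variation on a shared quinolinone core and cell toxicity

The compounds below may be only part of what the source reports. "The series", "measured", "known", "first", "only" and "open" are said of these compounds alone.

Measured compounds:
Compound 1, `COCC(=O)OCCc1c(-c2ccccc2Cl)c2cc(Cl)ccc2[nH]c1=O`, gives 74000 nM in an ADME assay on HepG2 2.2.15 cells (Homo sapiens) for cytotoxicity; on this read-out higher numbers stand for lower toxicity in this test and lower numbers for higher toxicity in this test.
Compound 2, `CC(=O)NCC(=O)OCCc1c(-c2ccccc2Cl)c2cc(Cl)ccc2[nH]c1=O`, gives 110000 nM in this assay.
Compound 3, `O=C(OCCc1c(-c2ccccc2Cl)c2cc(Cl)ccc2[nH]c1=O)C1CCCC1`, gives 46000 nM in this assay.

Compound 3 carries the lowest of the three numbers; compound 1 is nearest, and the gap a 1.6-fold lower number from compound 1 to compound 3 (0.21 log units; within the scatter) lies within the scatter, while the gap a 2.4-fold lower number from compound 2 to compound 3 (0.38 log units; beyond the scatter) is beyond it, modest in size. Compound 4, `O=C(CN1C(=O)c2ccccc2C1=O)OCCc1c(-c2ccccc2Cl)c2cc(Cl)ccc2[nH]c1=O`, differs from compound 3 by a group of 12 heavy atoms (9 carbon, 1 nitrogen, 2 oxygen; one five-membered non-aromatic ring with 1 hetero atom, one six-membered aromatic ring of carbon only) in place of a group of 5 heavy atoms (5 carbon; one five-membered non-aromatic ring of carbon only), on a carbonyl carbon. Among the measured compounds shown here, the steps that bear on this are the ones into compound 3 at the same carbonyl carbon: a 1.6-fold lower number from compound 1 to compound 3 (0.21 log units; within the scatter) and a 2.4-fold lower number from compound 2 to compound 3 (0.38 log units; beyond the scatter). Both replaced a chain bearing oxygen or nitrogen with cyclopentyl and moved the number down; the change to compound 4 goes the other way, bringing in a group with nitrogen and two acceptors, so a modest rise is expected. Compound 4 is therefore estimated at 80000 nM, within 35000 nM to 180000 nM, an expected step of a 1.7-fold higher number from compound 3 to compound 4 (0.24 log units; within the scatter).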

Compound 4, half-maximal cytotoxic concentration: 960000 nM
Compound 4: the middle estimate sits 12-fold (1.08 log units) below what was measured; measured number above the stated range.
By their numbers in this assay, from the lowest: compounds 3, 1 and 2 (each within the scatter of the next, the first and the last beyond it); then compound 4.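

On a carbonyl carbon, the group that enters in compound 4 moves the number in this assay far beyond the range of the other three compounds (a 21-fold higher number from compound 3 to compound 4 (1.32 log units; beyond the scatter)) and (a 13-fold higher number from compound 1 to compound 4 (1.11 log units; beyond the scatter)) and (an 8.7-fold higher number from compound 2 to compound 4 (0.94 log units; beyond the scatter)). The exchanges among methoxymethyl, acetamidomethyl and cyclopentyl had shown only small movement at this place, so these steps show that it can carry a much larger change, and that the rise appears whichever of the three groups leaves. Nothing available explains the size of this rise.

As far as these compounds go, it remains open whether the whole two-ring group is needed or only part of it. A benzoylamino group, a plain amine or a carboxylic acid on a saturated chain carbon bound to a carbonyl carbon could separate these possibilities.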